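A Urea in Place of the Sulfonamide on the Aryl Amine

A few compounds are considered here, and "the series" means these few. Any claim that something is new, unique, unknown or untested is made for them only; others in the source may bear on it.

Compound 1 `O=C(Nc1ccc(-c2noc(-c3cccc(NS(=O)(=O)c4ccccc4)c3)n2)c(Cl)c1)c1cccnc1` sits at the edge of what a functional assay on MDA-MB-231 cells (Homo sapiens) for antiproliferative activity, read by MTT assay, with a stated time of 72 h (on this read-out higher numbers stand for weaker inhibition and lower numbers for stronger inhibition), can report: for compound 1 the result is a limit, > 10000 nM, rather than a number (the limit of > 10000 nM in this assay, at which 1 of the 2 values shown sits). Going by the values given here, compound 2 `CNC(=O)Nc1ccc(S(=O)(=O)Nc2cccc(-c3nc(-c4ccc(NC(=O)c5cccnc5)cc4Cl)no3)c2)cc1` gives 1300 nM in this assay, so that the step of an at least 7.6-fold lower number from compound 1 to compound 2 (0.88 log units; beyond the scatter) is the only measured change in this set, and it shows that adding a carbamoyl-bearing nitrogen to the shared core can lower the number clearly. Compound 3 `O=C(Nc1ccc(Cl)cc1)Nc1cccc(-c2nc(-c3ccc(NC(=O)c4cccnc4)cc3Cl)no2)c1` has not yet been measured; it differs from compound 1 by (4-chlorophenyl)carbamoyl in place of phenylsulfonyl on a nitrogen on an aromatic ring. That change also brings in a carbamoyl group, but it removes the sulfonyl rather than adding to it, so the measured step is only a loose guide. A modest gain is expected: compound 3 is estimated at 3500 nM, within 900 nM to 15000 nM, which would be the expected step of an at least 2.8-fold lower number from compound 1 to compound 3 (0.45 log units; beyond the scatter).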

Compound 3, half-maximal inhibitory concentration: > 10000 nM
Compound 3 gave a limit, no number; the forecaster's own chance of this, stated with the estimate: 35%; middle value at least 2.8-fold (0.45 log units) away from the limit.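

Compound 3, like compound 1, gives only a limit in this assay and not a number, so the step between compound 1 and compound 3 cannot be read: the limit of > 10000 nM in this assay, at which 2 of the 3 values shown sit. The compounds shown leave open whether (4-chlorophenyl)carbamoyl in place of phenylsulfonyl changes antiproliferative activity at all.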